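This account rests on a few compounds, and the source may have more. Where it says the series, first, only, none or still open, it means among the compounds named here.

Measured so far:
compound 1 `Clc1ccc(C2=NN(c3ccc(-c4ccccc4)nn3)C(c3ccc(Cl)cc3)C2)cc1`: 10000 nM
compound 2 `COc1ccc(C2=NN(c3ccc(-c4ccccc4)nn3)C(c3ccccc3)C2)cc1`: > 100000 nM

In a functional assay on HepG2 cells (Homo sapiens) for antiproliferative activity, read by MTT assay, with a stated time of 24 h (on this read-out higher numbers stand for weaker inhibition and lower numbers for stronger inhibition), compound 1 gives 10000 nM, a true number. Compound 2 is different: in this assay compound 2 reaches only the limit of > 100000 nM, so no number is known for it. Compound 2 thus stands at the limit of > 100000 nM in this assay, at which 1 of the 2 values shown sits, the one of the two measured compounds whose result is a limit rather than a value.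

The unmeasured compound 3 `COc1ccc(C2=NN(c3ccc(-c4ccccc4)nn3)C(c3ccc(Cl)cc3)C2)cc1` differs from compound 2 by chloro in place of hydrogen on an aromatic carbon; the same difference, cut one bond further out, reads phenyl to 4-chlorophenyl. Among the compounds with values here, no pair of measured compounds that differ in one place is available, so the size of this step in this assay cannot be read from a measured comparison. Compound 1, which carries a 4-chlorophenyl at the same position, gives a number where compound 2 does not, which suggests stronger inhibition for compound 3, of unknown size. The step from compound 2 to compound 3 is expected to be an at least 2.0-fold lower number from compound 2 to compound 3 (0.30 log units; that floor lies within the scatter). Compound 3 is expected at 50000 nM, within 12000 nM to 200000 nM, with a sizeable chance that only a limit is returned.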

Compound 3, half-maximal inhibitory concentration: > 100000 nM
Compound 3: only a limit was reported; the forecaster's own chance of this, stated with the estimate: 45%; at least 2.0-fold (0.30 log units) between middle value and limit.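

In this assay, within the data shown here, methoxy in place of chloro on an aromatic carbon gives an at least 10-fold higher number from compound 1 to compound 3 (1.00 log units; beyond the scatter), the first readable step and a sign that the aromatic carbon carrying this exchange is sensitive to the group placed there. Compound 3 keeps the 4-chlorophenyl of compound 1, yet its result is only a limit, so in this pair the 4-chlorophenyl alone does not restore a measurable value once methoxy replaces chloro. The step for chloro in place of hydrogen cannot be read, as compound 2 and compound 3 share one limit: the limit of > 100000 nM in this assay, at which 2 of the 3 values shown sit.

The effect of the 4-chlorophenyl therefore remains open, both with methoxy, where any gain stays hidden by the limit, and with chloro at the exchanged position, where the phenyl counterpart of compound 1 is not among the compounds shown. Also open, as far as these compounds go, is whether only chloro gives a value at the exchanged position, or whether fluoro, trifluoromethyl or an amine there would also give one.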